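Notes on the sulfonate series: compound 3 to compound 4

This account rests on a few compounds, and the source may have more. Where it says the series, first, only, none or still open, it means among the compounds named here.

Measured so far:
compound 1 `CCC(=O)Nc1ccc(S(=O)(=O)Oc2ccccc2C(C)C)cc1` 11000 nM
compound 2 `CC(C)c1ccccc1OS(=O)(=O)c1ccc(NC(=O)CCCl)cc1` 14000 nM
compound 3 `CC(C)c1ccccc1OS(=O)(=O)c1ccc(NC(=O)CCCCl)cc1` 5100 nM

In a functional assay on M21 cells (Homo sapiens) for antiproliferative activity, read by sulforhodamine B assay, with a stated time of 48 h (a higher number here means a weaker inhibitor, a lower number a stronger inhibitor), compound 3 holds the lowest number of the three; the steps of a 2.2-fold lower number from compound 1 to compound 3 (0.33 log units; beyond the scatter) and a 2.7-fold lower number from compound 2 to compound 3 (0.44 log units; beyond the scatter) are both modest, while a 1.3-fold higher number from compound 1 to compound 2 (0.10 log units; within the scatter) is within the scatter. Compound 4 `CCCNC(=O)Nc1ccc(S(=O)(=O)Oc2ccccc2C(C)C)cc1` differs by propylamino in place of 3-chloropropyl on a carbonyl carbon, that is, the same difference cut one bond further out reads (3-chloropropyl)carbonyl to propylcarbamoyl. Going by the values given here, no measured step changes this carbonyl neighbour, so the three steps bear only loosely on it; they show that the chain end matters modestly at best. With the chlorine gone, a return toward the number of compound 1 is expected, a step of about a 2.0-fold higher number from compound 3 to compound 4 (0.29 log units; within the scatter). Compound 4 is estimated at 10000 nM, within 3000 nM to 40000 nM.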

Compound 4, half-maximal inhibitory concentration: 5100 nM
Compound 4: middle estimate off by 2.0-fold (0.29 log units), on the high side; the measured number falls inside the stated range.
By their numbers in this assay, from the lowest: compounds 3 and 4 (each within the scatter of the next); then compounds 1 and 2 (each within the scatter of the next).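

Propylamino in place of 3-chloropropyl on a carbonyl carbon whose other neighbour is an amide-type nitrogen (no change at the digits printed from compound 3 to compound 4 (within the scatter)) shows that in this assay a chain without chlorine can match the number of the chloro chain of compound 3. Against the shorter chains, propylamino gives (a 2.7-fold lower number from compound 2 to compound 4 (0.44 log units; beyond the scatter)) and (a 2.2-fold lower number from compound 1 to compound 4 (0.33 log units; beyond the scatter)), both modest steps. Nothing available accounts for this result.

Open, as far as these compounds go, is whether a butylamino chain, a dimethylamino group or a carboxylic acid at the chain end on this carbonyl carbon would shift the number. Also open, from the compounds shown here alone, is whether chlorine at the end of the propylamino chain would change it.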